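Fluorinated benzyl substitution on the shared core

The source may report more compounds than this note shows. Statements on the series, on what has been measured and on what is new or still open speak of the compounds shown alone.

Compound 1, `CCCn1c(=O)c2nc(-c3cnn(Cc4cccc(C)c4)c3)[nH]c2n(CCC)c1=O`, carries a 3-methylbenzyl group and is the reference point of this set. In an in vitro assay on HEK293 cells for displacement of a labelled ligand from adenosine receptor A2b (Homo sapiens) (a lower number here means a stronger inhibitor, a higher number a weaker inhibitor), compound 1 gives 36 nM, the lower of the two numbers available. Compound 2, `CCCn1c(=O)c2nc(-c3cnn(Cc4cc(C(F)(F)F)cc(Cl)c4F)c3)[nH]c2n(CCC)c1=O`, keeps the same core and in this assay gives 360 nM, a higher number that lies beyond the scatter of the method. Compound 3, `CCCn1c(=O)c2c(nc(-n3cc(I)cn3)n2Cc2ccccc2)n(CCC)c1=O`, reaches only a limit in this assay, namely > 5800 nM; this is the limit of > 5800 nM in this assay, at which 1 of the 3 values shown sits, so no number is available for compound 3.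

Compound 4, `CCCn1c(=O)c2nc(-c3cnn(Cc4c(F)cc(F)cc4F)c3)[nH]c2n(CCC)c1=O`, has not yet been measured. It differs from compound 1 in one place: 2,4,6-trifluorophenyl in place of 3-methylphenyl on a saturated chain carbon bound to an aromatic nitrogen. Going by the values given here, no step between measured compounds isolates this change, so its size has to be estimated. Compound 2 shows that a heavily halogenated benzyl group is tolerated with loss of potency, and the 2,4,6-trifluorophenyl group of compound 4 is smaller than the group found in compound 2. For compound 4 the expected step is a 2.2-fold higher number from compound 1 to compound 4 (0.35 log units; beyond the scatter), a modest weakening that may fall close to the scatter. The value expected for compound 4 in this assay is 80 nM, with a range from 25 nM to 300 nM.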

Compound 4, inhibition constant: 650 nM
Beside the measured number, compound 4's estimate is 8.1-fold (0.91 log units) below it, and the stated range ends below it.
By their numbers in this assay, from the lowest: compound 1; then compounds 2 and 4 (each within the scatter of the next). At a limit, above all of these: compound 3.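

At this position the change from 3-methylphenyl to 2,4,6-trifluorophenyl, on a saturated chain carbon bound to an aromatic nitrogen, now has a measured size in this assay: an 18-fold higher number from compound 1 to compound 4 (1.26 log units; beyond the scatter) is a large step and the first that can be read for this group. Going by these compounds alone, the earlier compounds showed only that compound 2, with its chloro, fluoro and trifluoromethyl benzyl group, has a higher number than compound 1; compound 4 shows that a benzyl group carrying fluorine alone also has a higher number than compound 1, and compound 4 and compound 2 lie within the scatter of each other. The limit reached by compound 3 belongs to a differently built compound and does not bear on this step, so nothing shown accounts for its size.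

Within the data shown here, the single step replaces the methyl group and adds the three fluorines in one change, so the share of each stays open, and an unsubstituted benzyl group or a benzyl group carrying one fluorine would separate them. Going by these compounds, how a methoxy group, an amine or a carboxylic acid on the phenyl ring would read in this assay also remains open.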